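Adding isobutyl to a weakly active methyl ester

This account rests on a few compounds, and the source may have more. Where it says the series, first, only, none or still open, it means among the compounds named here.

In a functional assay on MCF7 cells (Homo sapiens) for antiproliferative activity, read by MTT assay, with a stated time of 48 h (a lower number here means a stronger inhibitor, a higher number a weaker inhibitor), compound 1 (`CC[C@@H](C)[C@H](NC(=O)c1ccc(Oc2nc3ccccc3nc2C)cc1)C(=O)OC`) gives 36100 nM as a measured number. Compound 2 (`COC(=O)CNC(=O)c1ccc(Oc2nc3ccccc3nc2NC(C)(C)C)cc1`) gives > 50000 nM, and this is a limit of the assay, not a number. Compound 3 (`COC(=O)[C@H](CC(C)C)NC(=O)c1ccc(Oc2nc3ccccc3nc2NC(C)(C)C)cc1`) has isobutyl in place of hydrogen on a saturated chain carbon bound to an amide-type nitrogen and a carbonyl carbon. Going by the values given here, no measured pair shows this change alone. Among the compounds with values here, compound 1 is the only guide, and its value (36100 nM) suggests activity stays weak. A small shift toward stronger inhibition is expected in this assay (an at least 1.4-fold lower number from compound 2 to compound 3 (0.15 log units; that floor lies within the scatter)). Compound 3 is estimated at 35000 nM, with an expected range of 15000 nM to 50000 nM.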

Compound 3, half-maximal inhibitory concentration: > 50000 nM
Compound 3 was reported as a limit (the forecaster's own chance of this, stated with the estimate: 40%); at least 1.4-fold (0.15 log units) between middle value and limit.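

No step can be read from compound 2 to compound 3, because both stop at the same limit rather than a number: the limit of > 50000 nM in this assay, at which 2 of the 3 values shown sit. On these data alone, whether isobutyl in place of hydrogen changes activity at all remains open.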